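A few compounds are considered here, and "the series" means these few. Any claim that something is new, unique, unknown or untested is made for them only; others in the source may bear on it.

The study opens with compound 1, `Cn1cc(-c2ccc(C(F)F)cc2)c2cc(F)c(C(=O)NS(=O)(=O)C3CC3)cc21`. Going by the values given here, in an ADME assay on microsomes from liver (Rattus norvegicus) for metabolic stability, with a stated time of 10 min, tested at 0.5 uM (a lower number here means that less of the compound is left, a higher number that more of the compound is left), compound 1 gives 82%, the lowest of the two numbers known so far. The nearest is compound 2, `CC(C)COc1ccc(-c2nn(C)c3cc(C(=O)NS(=O)(=O)C4CC4)c(F)cc23)cn1`, which in this assay gives 88%, a number within the scatter of compound 1, so the two stand together rather than one above the other.

Compound 3, `Cn1cc(-c2ccc(C(F)(F)F)cc2)c2cc(F)c(C(=O)NS(=O)(=O)C3CC3)cc21`, has not been measured in this assay. Compound 3 differs from compound 1 by a single change: fluoro in place of hydrogen on a saturated chain carbon bound to an aromatic carbon and two fluorine atoms.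

Among the compounds with values here, no step between two measured compounds that differ in one place is known, so there is nothing of that kind to lean on. Since compound 1 already leaves most of the compound remaining with 82%, the room to rise is small. The step is expected to be a number 3 percentage points higher from compound 1 to compound 3 (within the scatter), nothing beyond the scatter. The estimate for compound 3 in this assay is 85%, within a range from 72% to 95%.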

Compound 3, percent of the compound remaining: 100%
Compound 3: the middle estimate sits 15 percentage points below what was measured; the whole stated range lies below it.
By their numbers in this assay, from the lowest: compounds 1 and 2 (each within the scatter of the next); then compound 3.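

In this assay, going by these compounds alone, the change from difluoromethyl to trifluoromethyl gives a number 18 percentage points higher from compound 1 to compound 3 (beyond the scatter) and is the first single-place step, showing that one fluoro in place of hydrogen on this saturated chain carbon can move the read-out beyond the scatter. Compound 1 already stood high at 82% and yet this carbon still left room for a clear step, so a high starting number did not rule out a change here. No measurement at hand bears on the reason for this step.

On these data alone, it stays open whether the step belongs to fluoro alone or would also appear with a chloro or a methyl on the same carbon. As far as these compounds go, a nitrile in place of the whole trifluoromethyl group remains equally open, as does the fate of this change on the core of compound 2.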